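Replacing nitro with carboxy on the shared core

This account rests on a few compounds, and the source may have more. Where it says the series, first, only, none or still open, it means among the compounds named here.

Measured so far in a physicochemical assay for acid dissociation, are three compounds

- compound 1 `NS(=O)(=O)c1ccc(SCCCO)c(Cl)c1` gives 9.45
- compound 2 `NS(=O)(=O)c1ccc(SCCO)c(F)c1` gives 9.76
- compound 3 `NS(=O)(=O)c1ccc(SCCO)c([N+](=O)[O-])c1` gives 9.42

Compound 3 stands level with compound 1 within the scatter and clearly under compound 2. Compound 4 `NS(=O)(=O)c1ccc(SCCO)c(C(=O)O)c1` is not yet measured. It carries carboxy in place of nitro on an aromatic carbon, ortho to a (2-hydroxyethyl)sulfanyl group and meta to a sulfamoyl group carboxy in place of nitro on an aromatic carbon in its structure. Within the data shown here, only one measured step bears on this change, the modest a number 0.34 log units lower from compound 2 to compound 3 (beyond the scatter) on putting nitro in place of fluoro. Among the measured compounds shown here, no measured compound carries carboxy, so the reverse direction is only a cautious guide. A modest rise of similar size is expected, and the estimated change is a number 0.38 log units higher from compound 3 to compound 4 (beyond the scatter) in this assay for now. The estimate for compound 4 is 9.8 with an expected range of 9.4 to 10.2 as the likely span.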

Compound 4, acid dissociation constant: 10.5
Beside the measured number, compound 4's estimate is 0.70 log units below it, and the stated range ends below it.
By their numbers in this assay, from the lowest: compounds 3 and 1 (each within the scatter of the next); then compound 2; then compound 4.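

In this assay the read-out with carboxy on the carbon ortho to a (2-hydroxyethyl)sulfanyl group turns out higher than the nitro and fluoro compounds alone suggested. Carboxy there gives a number 1.08 log units higher from compound 3 to compound 4 (beyond the scatter) and a number 0.74 log units higher from compound 2 to compound 4 (beyond the scatter) as well, so compound 4 stands clearly above both. The swap of nitro for carboxy, two groups of equal heavy-atom count, thus moves the read-out further than the earlier step between fluoro and nitro did.

Whether an amine or a methyl ester on this carbon would fall nearer compound 4 or compound 3 stays open, and nothing available here accounts for the size of this rise.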